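Urea aryl swap: phenyl to naphthalen-2-yl, cytotoxicity

The source may hold more compounds than are shown below. What is called first, only, known or untested is meant among the compounds shown, and "the series" means these compounds.

Measured so far in an ADME assay on Vero cells (Chlorocebus sabaeus) for cytotoxicity, read by resazurin assay, with a stated time of 2 days; a lower number here means that less compound is tolerated, a higher number that more compound is tolerated:
compound 1 `O=C(/C=C/c1ccc(NC(=S)Nc2ccccc2)cc1)C[C@@H]1O[C@H](CO)[C@@H](O)[C@H](O)[C@H]1O` gives 274000 nM;
compound 2 `O=C(/C=C/c1ccc(NC(=O)Nc2ccccc2)cc1)C[C@@H]1O[C@H](CO)[C@@H](O)[C@H](O)[C@H]1O` gives 1130000 nM.

For the measured compounds named here, compound 2 stands highest of the two numbers; its nearest neighbour is compound 1, and the only measured step, a 4.1-fold higher number from compound 1 to compound 2 (0.62 log units; beyond the scatter), concerns the thiourea to urea exchange rather than the aryl ring. Compound 3 `O=C(/C=C/c1ccc(NC(=O)Nc2ccc3ccccc3c2)cc1)C[C@@H]1O[C@H](CO)[C@@H](O)[C@H](O)[C@H]1O` keeps the urea of compound 2 and carries naphthalen-2-yl in place of phenyl on an amide-type nitrogen. Going by the values given here, no measured step bears on this kind of change; the thiourea to urea step gives no guidance on enlarging the aryl group. With nothing to anchor it, the expectation for this assay is a move no larger than modest, more likely toward a lower number than a higher one, and possibly within the scatter. Compound 3 is estimated at 600000 nM, with a range of 250000 nM to 1300000 nM. The expected step is a 1.9-fold lower number from compound 2 to compound 3 (0.27 log units; within the scatter).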

Compound 3, half-maximal cytotoxic concentration: 1020000 nM
Compound 3: middle estimate off by 1.7-fold (0.23 log units), on the low side; low and high end bracket the measured number.
By their numbers in this assay, from the lowest: compound 1; then compounds 3 and 2 (each within the scatter of the next).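

In this assay, naphthalen-2-yl in place of phenyl on an amide-type nitrogen gives a 1.1-fold lower number from compound 2 to compound 3 (0.04 log units; within the scatter), so within the urea pair this aryl enlargement leaves the number unresolved from that of compound 2. For the compounds shown here, this is the first measured change at this position, and the added aromatic ring produces no step beyond the scatter, whereas the exchange of thiourea for urea does, at a 4.1-fold higher number from compound 1 to compound 2 (0.62 log units; beyond the scatter). No supporting data bear on why the aryl change leaves the number unresolved.

Only two aryl groups on the urea are shown, so it remains open whether a group carrying an amine or a carboxylic acid on the aromatic ring would also leave the number unresolved. Also open, on these data alone, is whether naphthalen-2-yl on the thiourea would behave as it does on the urea.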